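A few compounds are considered here, and "the series" means these few. Any claim that something is new, unique, unknown or untested is made for them only; others in the source may bear on it.

Compound 1 `O=S(=O)(c1ccc(F)c(F)c1)c1cnc2cc(F)ccc2c1-c1ccc(Cl)cc1` gives 1.41 mL/min in an ADME assay on microsomes from liver (Rattus norvegicus) for metabolic stability, tested at 2.5 uM; on this read-out lower numbers stand for slow clearance and higher numbers for fast clearance.
Compound 2 `O=S(=O)(c1ccc(F)cc1)c1cnc2cc(F)ccc2c1-c1ccc(Cl)cc1` gives 0.89 mL/min in this assay.

Within the data shown here, compound 2 has the lower of the two numbers, but its only neighbour is compound 1, and the step of a 1.6-fold lower number from compound 1 to compound 2 (0.20 log units; within the scatter) lies within the scatter, so the two compounds cannot be told apart on this read-out. Compound 3 `O=S(=O)(c1ccc(F)cc1)c1cnc2cc(Cl)ccc2c1-c1ccc(Cl)cc1` is not yet measured. It differs from compound 2 by chloro in place of fluoro on an aromatic carbon. Among the measured compounds shown here, the single measured step, from compound 1 to compound 2, concerns a fluoro on a different ring and was small, so no measured step bears directly on the change to compound 3, and nothing in the data points to a large move in either direction. A step of a 1.1-fold higher number from compound 2 to compound 3 (0.05 log units; within the scatter) within the scatter is therefore expected. Compound 3 is estimated at 1 mL/min, with a range from 0.5 mL/min to 2 mL/min.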

Compound 3, intrinsic clearance in a liver preparation (reported as CLH), per the amount of preparation that the assay uses: 0.01 mL/min
Estimate against measurement, compound 3: 100-fold (2.00 log units) above; measured number outside the range, below it.
By their numbers in this assay, from the lowest: compound 3; then compounds 2 and 1 (each within the scatter of the next).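

At this position, on an aromatic carbon of a six-membered aromatic ring of carbon only, part of a fused or bridged system of two rings, the halogen matters far more in this assay than the earlier change on a different ring: chloro in place of fluoro gives an 89-fold lower number from compound 2 to compound 3 (1.95 log units; beyond the scatter), whereas the earlier change gave only a 1.6-fold lower number from compound 1 to compound 2 (0.20 log units; within the scatter). The swap exchanges one heavy atom for one heavy atom and leaves the hydrogen-bond donor and acceptor counts and the net charge unchanged, so a very small structural change can carry a large change in this read-out. Nothing available explains the size of this step.

As far as these compounds go, whether the drop is special to chloro or would also appear with bromo, methyl or methoxy at this place remains open. From the compounds shown here alone, it is also open whether chloro would have the same effect on compound 1, which carries the second fluoro.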